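Cyano-to-carbamoyl change on a shortened ether chain

The source may report more compounds than this note shows. Statements on the series, on what has been measured and on what is new or still open speak of the compounds shown alone.

Measured so far:
compound 1 `CCc1cc(C(C)=O)c(O)cc1OCCCCCCC(C)(C)C#N`: 11%
compound 2 `CCc1cc(C(C)=O)c(O)cc1OCCCCCCCC(C)(C)C#N`: 6%

In an assay on isolated protein for binding affinity to leukotriene B4 receptor (Homo sapiens), tested at 0.1 uM (a higher number here means more inhibition at the concentration tested (going by the name of the read-out), a lower number less inhibition), compound 1 gives 11%, the higher of the two numbers, while compound 2 gives 6%; the step of a number 5 percentage points lower from compound 1 to compound 2 (within the scatter) is within the scatter. Compound 3 `CCc1cc(C(C)=O)c(O)cc1OCCCC(C)(C)C(N)=O` differs from compound 1 by 1-carbamoyl-1-methylethyl in place of 4-cyano-4-methylpentyl on a saturated chain carbon, three bonds along the chain from an oxygen on an aromatic ring. Going by the values given here, the only measured step, from compound 1 to compound 2, touches neither the carbamoyl group nor the shorter chain, so it gives little guidance. With both measured numbers low and close, no step beyond the scatter is expected: a number 3 percentage points lower from compound 1 to compound 3 (within the scatter). Compound 3 is estimated at 8%, with a range from 0% to 22%.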

Compound 3, a percentage reported as inhibition, at one concentration (the size of the read-out at that concentration, not a potency): 16%
The estimate for compound 3 lay 8 percentage points below the measured number; the range from low to high includes it.
By their numbers in this assay, from the lowest: compounds 2, 1 and 3 (each within the scatter of the next).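

In this assay, going by these compounds alone, the change to 1-carbamoyl-1-methylethyl gives a number 5 percentage points higher from compound 1 to compound 3 (within the scatter) and is the first step to alter both the chain length and the terminal group. Neither the nitrile nor the 4-cyano-4-methylpentyl chain is therefore needed to keep the number in this low range. No supporting data bear on this result.

The separate contributions of the shorter chain and the carbamoyl group remain unresolved. Also open, as far as these compounds go, is whether a carboxylic acid or a primary amine at the chain end would give a step beyond the scatter.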